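A few compounds are considered here, and "the series" means these few. Any claim that something is new, unique, unknown or untested is made for them only; others in the source may bear on it.

Of the compounds shown here, three have been measured in an assay on isolated protein for inhibition of 3',5'-cyclic-AMP phosphodiesterase 4A (Cavia porcellus), read by cAMP accumulation, tested at 10 uM; a lower number here means a weaker effect, a higher number a stronger effect of the compound at the concentration tested. Compound 1, `O=C1CC(c2ccccc2)Cc2[nH]c(=O)c(C(=O)c3ccccc3)cc21`, gives 5.2% in this assay. Compound 2, `O=C1CC(c2ccccc2)Cc2[nH]c(=O)c(S(=O)(=O)c3ccccc3)cc21`, gives 0%, and the step of a number 5.2 percentage points lower from compound 1 to compound 2 (within the scatter) lies within the scatter. Compound 3, `CC(C)(C)C(=O)c1cc2c([nH]c1=O)CCCC2=O`, gives 2.5%, the second highest of the three numbers; its nearest neighbour is compound 2 and its furthest compound 1, and both gaps lie within the scatter, so the three compounds cannot be told apart on these numbers.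

Compound 4, `CC(C)(C)C(=O)c1cc2c([nH]c1=O)CC(c1ccccc1)CC2=O`, differs from compound 3 by phenyl in place of hydrogen on a saturated ring carbon. Among the measured compounds shown here, no measured step touches this position: compounds 1 and 2 already carry the phenyl there, and compound 1 and compound 3 differ in more than one place, so their two values show only that both are small. For the measured compounds named here, the single measured step, a number 5.2 percentage points lower from compound 1 to compound 2 (within the scatter), concerns a different group and stays within the scatter. With every number low and close, compound 4 is expected to move by a number 1.5 percentage points higher from compound 3 to compound 4 (within the scatter), nothing beyond the scatter. The estimate for compound 4 is 4%, between 0% and 15%.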

Compound 4, a percentage reported as inhibition, at one concentration (the size of the read-out at that concentration, not a potency): 0.8%
For compound 4 the middle estimate is 3.2 percentage points above the measured one, and the stated range covers the measured number.
By their numbers in this assay, from the lowest: compounds 2, 4, 3 and 1 (each within the scatter of the next).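

In this assay, among the compounds shown here, phenyl in place of hydrogen on a saturated ring carbon gives a number 1.7 percentage points lower from compound 3 to compound 4 (within the scatter), the first measured step at this position, and it cannot be told from the scatter. On the aromatic carbon, (tert-butyl)carbonyl in place of phenylsulfonyl gives a number 0.8 percentage points higher from compound 2 to compound 4 (within the scatter) and tert-butyl in place of phenyl on the carbonyl carbon gives a number 4.4 percentage points lower from compound 1 to compound 4 (within the scatter), so neither change stands out either. Nothing available explains why these numbers stay so small.

With all four numbers low and close together, the compounds shown do not reveal whether any of these groups matters for inhibition. On these data alone, whether an amine or a carboxylic acid on the saturated ring carbon, or a longer chain in place of tert-butyl, would lift the number clear of the scatter stays open.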